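The compounds below may be only part of what the source reports. "The series", "measured", "known", "first", "only" and "open" are said of these compounds alone.

Compound 1 `CCCCC[Se]c1nc([Se]CCCCC)c2cccnc2n1` is tested in a functional assay on HT-29 cells (Homo sapiens) for cytotoxicity, read by MTT assay, with a stated time of 72 h (on this read-out lower numbers stand for higher toxicity in this test and higher numbers for lower toxicity in this test), and for compound 1 the result in this assay is a limit of the assay, > 100000 nM, not a number. Two related compounds sit in the same position. Compound 2 `[SeH]c1nc(NCc2ccccc2)c2cccnc2n1` gives in this assay only a limit, > 100000 nM. Compound 3 `CCCCCSc1nc(NCc2ccc([Se]C)cc2)c2ccccc2n1` likewise gives in this assay only a limit, > 100000 nM. Within the data shown here, compound 1 therefore stands where every value shown stands, at the limit of > 100000 nM in this assay, at which 3 of the 3 values shown sit, and no compound in this set has a measured number to compare against.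

The unmeasured compound 4 `CCCCC[Se]c1nc(N)c2cccnc2n1` differs from compound 1 in a single place: one nitrogen atom in place of a group of 6 heavy atoms (5 carbon, 1 selenium; no ring), on an aromatic carbon, on an aromatic carbon of a six-membered aromatic ring with two nitrogens, next to the ring nitrogen, part of a fused system of two rings. The selenium-containing chain on the other side of the core is kept.

Among the measured compounds shown here, no step between measured compounds exists here, so no measured size of change is available. With all three known values at the limit, compound 4 is expected to remain near that limit, and the step of a number no higher from compound 1 to compound 4 (the limit leaves the size open) is expected to be small, within the scatter in either direction. For compound 4 the expected result in this assay is 100000 nM, with a range from 30000 nM to 300000 nM, and a high chance that only a limit is reported again.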

Compound 4, concentration lethal to 50% of the cells: 62100 nM
Compound 4: the middle estimate sits 1.6-fold (0.21 log units) above what was measured; the range from low to high includes it.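

In this assay, putting amino in place of the group of 6 heavy atoms on this aromatic carbon gives the first result in the set that is a number and not a limit, and it reads as an at least 1.6-fold lower number from compound 1 to compound 4 (0.20 log units; that floor lies within the scatter). The value for compound 1 is a limit, so this step has a floor but no fixed size, and the true change at this position could be small or considerably larger. The single change is therefore enough to bring compound 4 to a measured value in this test, where the other compounds shown give no number to compare with: the limit of > 100000 nM in this assay, at which 3 of the 4 values shown sit.

The compounds shown leave open whether amino in particular matters here, or whether a methylamino group, a hydroxyl group or a shorter selenium-bearing chain in the same place would also give a measured number. They also leave open how a benzylamino group at this position would behave with the rest of compound 4 unchanged, and what replacing the remaining selenium-bearing chain with a sulfur-bearing chain would do.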